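From compound 3 to compound 4: swapping one ring group

A few compounds are considered here, and "the series" means these few. Any claim that something is new, unique, unknown or untested is made for them only; others in the source may bear on it.

- compound 1 `COc1ccc(C(F)(F)F)cc1Nc1ncc(C(F)(F)F)c(N2Cc3cccc(N(C)S(C)(=O)=O)c3C2)n1` gives > 30000 nM (a limit)
- compound 2 `Cc1cc(Cl)ccc1Nc1ncc(C(F)(F)F)c(N2Cc3cccc(N(C)S(C)(=O)=O)c3C2)n1` gives 19600 nM
- compound 3 `Cc1ccc(Nc2ncc(C(F)(F)F)c(N3Cc4cccc(N(C)S(C)(=O)=O)c4C3)n2)c(C)c1` gives 19100 nM

In a functional assay on HepG2 cells (Homo sapiens) for antiproliferative activity, read by spectrophotometry, with a stated time of 2 days (a lower number here means a stronger inhibitor of growth, a higher number a weaker inhibitor of growth), compound 3 gives 19100 nM and stands level with compound 2 at 19600 nM (a 1.0-fold lower number from compound 2 to compound 3 (0.01 log units; within the scatter)). Compound 1 reports only a limit (> 30000 nM).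

Compound 4 `CN(c1cccc2c1CN(c1nc(Nc3cc(Cl)cc(C(F)(F)F)c3)ncc1C(F)(F)F)C2)S(C)(=O)=O` keeps the shared core but carries 3-chloro-5-(trifluoromethyl)phenyl in place of 2,4-dimethylphenyl on a nitrogen on an aromatic ring. For the measured compounds named here, three measured steps bear on this change. The step with methyl in place of chloro (a 1.0-fold lower number from compound 2 to compound 3 (0.01 log units; within the scatter)) gives no sign that a chloro alone moves the number. Going by the values given here, compound 1 is the only measured compound whose group on this nitrogen also holds a trifluoromethyl, and the steps away from it (an at least 1.5-fold lower number from compound 1 to compound 2 (0.18 log units; that floor lies within the scatter) and an at least 1.5-fold lower number from compound 1 to compound 3 (0.19 log units; that floor lies within the scatter)) rest on a limit. Together they hint, weakly, at a higher number rather than a lower one. The step is expected to be a 1.2-fold higher number from compound 3 to compound 4 (0.06 log units; within the scatter) and so to stay within the scatter. Compound 4 might also return only a limit. The estimated value for compound 4 is 22000 nM with an expected range of 9000 nM to 40000 nM in this measurement.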

Compound 4, concentration for 50% growth inhibition: 9900 nM
Compound 4: the middle estimate sits 2.2-fold (0.35 log units) above what was measured; low and high end bracket the measured number.
By their numbers in this assay, from the lowest: compounds 4, 3 and 2 (each within the scatter of the next). At a limit, above all of these: compound 1.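

In this assay, compound 4 gives a measured number, 9900 nM, while carrying a trifluoromethyl on the group at this nitrogen, so a trifluoromethyl there does not by itself mean a reading out of range. Set against the two groups that hold no trifluoromethyl, the new group makes little measurable difference, with a 1.9-fold lower number from compound 3 to compound 4 (0.29 log units; within the scatter) and a 2.0-fold lower number from compound 2 to compound 4 (0.30 log units; within the scatter), and neither step separates these compounds. Only one step goes further, an at least 3.0-fold lower number from compound 1 to compound 4 (0.48 log units; beyond the scatter), and it gives a floor rather than a size, for compound 1 reports only a limit: the limit of > 30000 nM in this assay, at which 1 of the 4 values shown sits.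

No compound shown carries the chloro or the trifluoromethyl alone on this phenyl ring, so what each contributes to the number for compound 4 cannot be told apart. Also open, from the compounds shown here alone, is what an amine or a carboxylic acid on this ring would do, and whether any such group would give a number beyond the scatter of compound 4.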